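Fluoro for chloro: from compound 3 to compound 4

The compounds below may be only part of what the source reports. "The series", "measured", "known", "first", "only" and "open" are said of these compounds alone.

Measured so far in a functional assay on UACC-62 cells (Homo sapiens) for cytotoxicity, read by MTT assay, with a stated time of 6 days; a higher number here means a weaker inhibitor, a lower number a stronger inhibitor:
Compound 1 `CC(=O)N[C@@H](CSC(=O)NCc1ccc(Cl)cc1)C(=O)O` reaches only a limit of the assay, > 200000 nM.
Compound 2 `COc1ccccc1NC(=O)SC[C@H](NC(C)=O)C(=O)O` likewise reaches only a limit, > 200000 nM.
Compound 3 `CC(=O)N[C@@H](CSC(=O)Nc1ccc(Cl)cc1)C(=O)O` gives 24 nM.

Within the data shown here, compound 3 thus stands as the only compound with an actual number; the other two sit at the limit of > 200000 nM in this assay, at which 2 of the 3 values shown sit. Compound 4 `CC(=O)N[C@@H](CSC(=O)Nc1ccc(F)cc1)C(=O)O` differs from compound 3 in one place: fluoro in place of chloro on an aromatic carbon. Among the measured compounds shown here, no pair of measured compounds differing in a single place is available, so nothing here shows how such a swap shifts the read-out. Fluoro and chloro are both halogens at the same position of the ring. For compound 4 the expected step is a 1.7-fold higher number from compound 3 to compound 4 (0.22 log units; within the scatter), no larger than the usual scatter. Compound 4 is therefore estimated at 40 nM, within 10 nM to 160 nM.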

Compound 4, half-maximal inhibitory concentration in the UACC-62 assay: 36 nM
Estimate against measurement, compound 4: 1.1-fold (0.05 log units) above, within the range that was stated.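

Among these compounds, in the UACC-62 assay this is the first pair of compounds that differ in one place: a 1.5-fold higher number from compound 3 to compound 4 (0.18 log units; within the scatter). Fluoro can therefore take the place of chloro on this aromatic carbon without a change that stands out from the scatter. In a physicochemical assay for solubility, in phosphate buffer, at pH 7.4 (on this read-out higher numbers stand for higher solubility and lower numbers for lower solubility), compound 3 gives 26 ug/mL and compound 4 gives 26 ug/mL, and nothing shown here offers a reason why the two halogens read alike.

On these data alone, whether a nitrile or an amine on the same carbon would keep such a low number stays open. So does the effect of a methyl ester in place of the carboxylic acid.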